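Halogen swap on the sulfonyl aryl in a cytotoxicity series

This account rests on a few compounds, and the source may have more. Where it says the series, first, only, none or still open, it means among the compounds named here.

Compound 1 `CC(O)(CS(=O)(=O)c1ccc(Cl)cc1)c1nc(-c2ccc([N+](=O)[O-])c(C(F)(F)F)c2)no1` and compound 2 `CC(O)(CS(=O)(=O)c1ccc(F)cc1)c1nc(-c2ccc([N+](=O)[O-])c(C(F)(F)F)c2)no1` share one core and differ only by chloro in place of fluoro on an aromatic carbon. In a functional assay on DU-145 cells (Homo sapiens) for cytotoxicity, read by MTT assay (a higher number here means a weaker inhibitor, a lower number a stronger inhibitor), compound 1 gives 91000 nM. For compound 2 this assay reports only a limit, > 100000 nM. The measured step of an at least 1.0-fold lower number from compound 2 to compound 1 (0.04 log units; that floor lies within the scatter) is therefore bounded by the limit of > 100000 nM in this assay, at which 2 of the 3 values shown sit. Compound 3 `CC(O)(CS(=O)(=O)c1ccc(F)cc1)c1nc(-c2ccc(F)c(Cl)c2)no1` rests on a second core; the difference between the two cores is not broken down here. For compound 3 this assay reports only a limit, > 100000 nM. Compound 4 `CC(O)(CS(=O)(=O)c1ccc(Cl)cc1)c1nc(-c2ccc(F)c(Cl)c2)no1` differs from compound 3 by chloro in place of fluoro on an aromatic carbon, the same change at the same place. The expected step of a number no higher from compound 3 to compound 4 (the limit leaves the size open) is taken to be small, which rests on the step of an at least 1.0-fold lower number from compound 2 to compound 1 (0.04 log units; that floor lies within the scatter) from the measured pair. Compound 4 is thus estimated at about 100000 nM in this assay, roughly between 50000 nM and 300000 nM.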

Compound 4, half-maximal inhibitory concentration: 35500 nM
Beside the measured number, compound 4's estimate is 2.8-fold (0.45 log units) above it; the measured number lies below the stated range.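

Chloro in place of fluoro on the sulfonyl aryl gives an at least 2.8-fold lower number from compound 3 to compound 4 (0.44 log units; beyond the scatter) in this assay, so a step of at least modest size appears on the core of compound 3. Neither core shows a higher number after the change, but this does not show that the size of the step carries over from one core to the other: the same change on two cores in this assay, an at least 1.0-fold lower number (0.04 log units; that floor lies within the scatter) from compound 2 to compound 1 and an at least 2.8-fold lower number (0.44 log units; beyond the scatter) from compound 3 to compound 4; the limit leaves it open whether they differ. The fluoro members compound 2 and compound 3 are known only as limits, so neither step has a fixed size: the limit of > 100000 nM in this assay, at which 2 of the 4 values shown sit.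

The compounds shown leave open how a bromo or a methyl group would read at the same aromatic carbon. Also open, as far as these compounds go, is whether the step holds on a core with a nitrile or a carboxylic acid on the other aryl ring.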